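Notes on compound 4 and its expected cytotoxicity

This account rests on a few compounds, and the source may have more. Where it says the series, first, only, none or still open, it means among the compounds named here.

The series is read in a functional assay on MCF7 cells (Homo sapiens) for cytotoxicity, read by CCK-8 assay, with a stated time of 72 h; a lower number here means a stronger inhibitor, a higher number a weaker inhibitor. Compound 1 `C=CCn1c(=O)/c(=C\c2cccc(C)c2)[nH]c(=O)/c1=C\c1ccccc1OC` gives 20700 nM, compound 2 `C=CCn1c(=O)/c(=C\c2cccc(F)c2)[nH]c(=O)/c1=C\c1ccccc1OC` gives 13700 nM, and compound 3 `COc1ccccc1/C=c1\c(=O)[nH]/c(=C/c2ccccc2Cl)c(=O)n1C` gives 200 nM. Compound 2 stands second highest of the three numbers: nearest to compound 1, furthest from compound 3, whose structure differs from it in more than one place. Among the measured compounds shown here, the only single-place step known, a 1.5-fold lower number from compound 1 to compound 2 (0.18 log units; within the scatter), is within the scatter. Compound 4 `C=CCn1c(=O)/c(=C\c2ccc(Cl)c(Cl)c2)[nH]c(=O)/c1=C\c1ccccc1OC` differs from compound 2 by 3,4-dichlorophenyl in place of 3-fluorophenyl on a double-bonded chain carbon bound to an aromatic carbon. For the measured compounds named here, no measured step bears directly on this change; the one step available is small, so a step in this assay near the scatter is expected, leaning toward a lower number if anything. Compound 4 is therefore estimated at 10000 nM, range 3000 nM to 30000 nM, which means a 1.4-fold lower number from compound 2 to compound 4 (0.14 log units; within the scatter) is expected.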

Compound 4, half-maximal inhibitory concentration: "not active" (no number reported)
No number was reported for compound 4; there is nothing to compare the estimate with.
By their numbers in this assay, from the lowest: compound 3; then compounds 2 and 1 (each within the scatter of the next).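

Among the compounds shown here, compound 4 is reported as "not active" without a number, so no step from compound 2 to compound 4 can be read. The compounds shown leave open how far 3,4-dichlorophenyl in place of 3-fluorophenyl shifts the read-out. No further data bear on this result.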